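The compounds below may be only part of what the source reports. "The series", "measured", "known", "first", "only" and "open" are said of these compounds alone.

For the measured compounds named here, compound 2 `O=C(/C=C/c1cccc(NS(=O)(=O)c2ccccc2Cl)c1)c1nc2ccccc2[nH]1` is one of two compounds measured in a functional assay on 143B cells (Homo sapiens) for antiproliferative activity, read by MTT assay, with a stated time of 48 h (a higher number here means a weaker inhibitor, a lower number a stronger inhibitor), where compound 2 gives 4790 nM. Going by the values given here, compound 1 `COc1ccc(C(=O)Nc2cccc(/C=C/C(=O)c3nc4ccccc4[nH]3)c2)cc1` gives 6330 nM in this assay, and the only recorded step, a 1.3-fold lower number from compound 1 to compound 2 (0.12 log units; within the scatter), lies within the scatter. Compound 3 `Cc1ccc(S(=O)(=O)Nc2cccc(/C=C/C(=O)c3nc4ccccc4[nH]3)c2)cc1C` differs from compound 2 by 3,4-dimethylphenyl in place of 2-chlorophenyl on a sulfonyl sulfur. Among the compounds with values here, no measured step alters the group on the sulfonyl sulfur, and the one recorded step was small, so the expected step of a 1.1-fold lower number from compound 2 to compound 3 (0.03 log units; within the scatter) is none beyond the scatter. Compound 3 is therefore estimated at 4500 nM, with a range from 1800 nM to 12000 nM.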

Compound 3, half-maximal inhibitory concentration: 5050 nM
Compound 3: middle estimate off by 1.1-fold (0.05 log units), on the low side, and the stated range covers the measured number.
By their numbers in this assay, from the lowest: compounds 2, 3 and 1 (each within the scatter of the next).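

Unlike the earlier step, which replaced the whole group on the nitrogen, this one changes only the group on the sulfonyl sulfur. In this assay the result is a 1.1-fold higher number from compound 2 to compound 3 (0.02 log units; within the scatter) and so 3,4-dimethylphenyl and 2-chlorophenyl cannot be told apart at this place. For the compounds shown here, both are single aromatic rings of carbon, so the comparison covers only this one kind of group. From the compounds shown here alone, whether a group of another kind on the sulfonyl sulfur, such as a methyl, an amine or a carboxylic acid-bearing ring, would give a step beyond the scatter remains open. Nothing measured here offers an explanation for this result.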